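Bromo to Azido on a Saturated Chain Carbon

The source may report more compounds than this note shows. Statements on the series, on what has been measured and on what is new or still open speak of the compounds shown alone.

Going by the values given here, compound 1 `BrCCCc1ccc(-c2ccc(-c3cccs3)s2)s1` is the only compound here with a plain number in an ADME assay on MDCK cells (Canis lupus familiaris) for cytotoxicity, read by MTT assay, with a stated time of 2 days; a lower number here means that less compound is tolerated, a higher number that more compound is tolerated; compound 1 gives 35300 nM. Compound 2 `BrCCCc1ccc(-c2ccc(-c3ccc(-c4cccs4)s3)s2)s1` reaches only a limit of the assay, > 200000 nM. Among the compounds with values here, the one measured change, an at least 5.6-fold higher number from compound 1 to compound 2 (0.75 log units; beyond the scatter), is a different kind of change from the one followed here. Compound 3 `[N-]=[N+]=NCCCc1ccc(-c2ccc(-c3cccs3)s2)s1` differs from compound 1 only by azido in place of bromo on a saturated chain carbon, three bonds along the chain from an aromatic carbon. Within the data shown here, no measured step bears on this change, so no step beyond the scatter is expected in this assay. Compound 3 is therefore estimated at 40000 nM, between 15000 nM and 120000 nM, which means an expected step of a 1.1-fold higher number from compound 1 to compound 3 (0.05 log units; within the scatter).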

Compound 3, half-maximal cytotoxic concentration: > 200000 nM
Compound 3 ended at the assay's limit; the forecaster's own chance of this, stated with the estimate: 10%; at least 5.0-fold (0.69 log units) between middle value and limit.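

In this assay, this place on the chain clearly matters: azido in place of bromo gives an at least 5.6-fold higher number from compound 1 to compound 3 (0.75 log units; beyond the scatter). The earlier step came from a change to the ring end of the molecule, whereas here the core of compound 1 stays the same and only the chain end differs. The full size of the step cannot be read, because compound 3 stands at a limit and not at a number: the limit of > 200000 nM in this assay, at which 2 of the 3 values shown sit.

From the compounds shown here alone, whether the loss of bromo or the arrival of azido matters more stays open. An amine or chloro at the same place could help separate the two.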